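The source may hold more compounds than are shown below. What is called first, only, known or untested is meant among the compounds shown, and "the series" means these compounds.

Notes on the series. In a functional assay on MGC-803 cells (Homo sapiens) for inhibition, read by MTT assay, with a stated time of 48 h (a lower number here means a stronger inhibitor, a higher number a weaker inhibitor), compound 1 `COc1cc(N(Cc2nc3ccccc3[nH]2)S(=O)(=O)c2ccc(Br)cc2)cc(OC)c1OC` gives 2190 nM. Compound 2 `COc1cc(N(Cc2nc3ccccc3[nH]2)C(=O)c2ccccc2)cc(OC)c1OC`, with benzoyl in place of (4-bromophenyl)sulfonyl on a nitrogen on an aromatic ring, reaches only > 50000 nM, which is a limit of this assay and not a number. The step of an at least 22-fold higher number from compound 1 to compound 2 (1.35 log units; beyond the scatter) is thus known only as a lower bound, resting on (the limit of > 50000 nM in this assay, at which 1 of the 2 values shown sits). Compound 3 `COc1ccc(C(=O)N(Cc2nc3ccccc3[nH]2)c2cc(OC)c(OC)c(OC)c2)cc1OC` differs from compound 2 by 3,4-dimethoxyphenyl in place of phenyl on a carbonyl carbon. Going by the values given here, no measured step bears on a change at the carbonyl carbon; the one step in hand concerns the group on the nitrogen, so it gives no direction for this change. Compound 2 stands at the limit of this assay. From that starting point, the step of a number no higher from compound 2 to compound 3 (the limit leaves the size open) is expected to be small or not resolvable. Compound 3 is therefore expected to give 50000 nM, within 12000 nM to 200000 nM, most probably again only as a limit.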

Compound 3, half-maximal inhibitory concentration: 22400 nM
Beside the measured number, compound 3's estimate is 2.2-fold (0.35 log units) above it; low and high end bracket the measured number.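

Going by these compounds alone, the first step at the carbonyl carbon shows that this position responds to substitution: in this assay, 3,4-dimethoxyphenyl in place of phenyl gives an at least 2.2-fold lower number from compound 2 to compound 3 (0.34 log units; beyond the scatter). Even so, compound 3 at 22400 nM retains a higher number than compound 1 at 2190 nM, so this change does not bring the amide back to the value of the sulfonamide. The value of compound 2, > 50000 nM, is a limit of the assay and not a number, so the size of this step is known only as a lower bound: the limit of > 50000 nM in this assay, at which 1 of the 3 values shown sits.

Still open, from the compounds shown here alone, is whether one methoxy group alone accounts for the step, and whether an amine or a carboxylic acid on the same ring would shift the number in the same direction. Also open, going by these compounds, is whether 3,4-dimethoxyphenyl would have a comparable effect on the sulfonyl group of compound 1.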